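This account rests on a few compounds, and the source may have more. Where it says the series, first, only, none or still open, it means among the compounds named here.

Compound 1 `O=S(=O)(Nc1ccc(-c2nc3ccccc3o2)cc1)c1ccc(Cl)s1` was tested in an assay on isolated protein for inhibition of malate dehydrogenase, mitochondrial (Sus scrofa), with stated times of 45 min and 30 min; a lower number here means a stronger inhibitor, a higher number a weaker inhibitor. In this assay compound 1 gives > 63000 nM, which is a limit of the assay rather than a number. Two related compounds sit at the same limit. Compound 2 `O=S(=O)(Nc1ccc2oc(-c3ccccc3)nc2c1)c1ccccc1Cl` gives > 63000 nM, again a limit. Compound 3 `COc1ccc(S(=O)(=O)Nc2ccc3oc(-c4ccccc4)nc3c2)cc1` gives > 63000 nM, also a limit. Among the measured compounds shown here, the one step between measured compounds, a step that the two limits leave unreadable from compound 2 to compound 3, therefore cannot be read in size. Where compound 1 stands is thus known only as a limit, and the same holds for the other two values shown: the limit of > 63000 nM in this assay, at which 3 of the 3 values shown sit.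

Compound 4 `C=Cc1ccc(S(=O)(=O)Nc2ccc(-c3nc4ccccc4o3)cc2)cc1` has not yet been measured. It differs from compound 1 in one place: 4-vinylphenyl in place of 5-chlorothiophen-2-yl on a sulfonyl sulfur. For the measured compounds named here, no measured step matches this change; the only measured step, a step that the two limits leave unreadable from compound 2 to compound 3, also alters the group on the sulfonyl sulfur but was left unreadable by its two limits. Going by the values given here, with every value shown resting at the limit, there is no measured step from which a direction could be taken, so no change beyond the scatter is expected in this assay. Compound 4 is therefore estimated at 100000 nM, with a range from 30000 nM to 300000 nM. This corresponds to an expected step that the limit leaves unreadable from compound 1 to compound 4 from compound 1 to compound 4.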

Compound 4, half-maximal inhibitory concentration: > 63000 nM
Compound 4 gave a limit, no number; the forecaster's own chance of this, stated with the estimate: 85%; the middle value is on the limit's open side.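

Compound 1 and compound 4 both rest at a limit of this assay rather than at a number, so the size of the step between them cannot be read. The compounds shown leave open whether any group on the sulfonyl sulfur can give a measurable inhibition, because every value so far sits at one limit: the limit of > 63000 nM in this assay, at which 4 of the 4 values shown sit.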